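The compounds below may be only part of what the source reports. "The series", "measured", "known", "first", "only" and "open" are said of these compounds alone.

Measured compounds:
Compound 1 `O=C(C1CC1)N1CCc2nc(C#Cc3ccccc3)sc2C1` gives only a limit in an assay on HEK293 cells for positive allosteric modulation of metabotropic glutamate receptor 5 (Homo sapiens), read by FLIPR, with a stated time of 1 h (a higher number here means that more compound is needed for the effect, a lower number that less compound is needed), namely > 10000 nM.
Compound 2 `CC1CC1C(=O)N1CCc2nc(C#Cc3ccccc3)sc2C1` gives 9.4 nM in this assay.
Compound 3 `COC1CC(C(=O)N2CCc3nc(C#Cc4ccccc4)sc3C2)C1` gives 640 nM in this assay.

Compound 3 carries the highest of the two actual numbers; its nearest neighbour is compound 2, with a 68-fold higher number from compound 2 to compound 3 (1.83 log units; beyond the scatter). Compound 4 `O=C(C1CCOCC1)N1CCc2nc(C#Cc3ccccc3)sc2C1` differs from compound 3 in one place: oxan-4-yl in place of 3-methoxycyclobutyl on a carbonyl carbon. Two measured steps change the group on that carbonyl carbon, an at least 15-fold lower number from compound 1 to compound 3 (1.19 log units; beyond the scatter) and a 68-fold higher number from compound 2 to compound 3 (1.83 log units; beyond the scatter), both large, so this position moves the number strongly, though these steps do not settle the direction for the new group. The one limit in the series concerns compound 1 only, (the limit of > 10000 nM in this assay, at which 1 of the 3 values shown sits). For compound 4 a moderate rise beyond the scatter is expected, a 2.3-fold higher number from compound 3 to compound 4 (0.37 log units; beyond the scatter). Compound 4 is estimated at 1500 nM, between 200 nM and 10000 nM.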

Compound 4, half-maximal effective concentration: 290 nM
Beside the measured number, compound 4's estimate is 5.2-fold (0.71 log units) above it; measured number inside the range.
By their numbers in this assay, from the lowest: compound 2; then compound 4; then compound 3. At a limit, above all of these: compound 1.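

In this assay, exchanging one six-atom oxygen-bearing group for another on the carbonyl carbon gives only a modest shift, a 2.2-fold lower number from compound 3 to compound 4 (0.34 log units; beyond the scatter), while oxan-4-yl remains well behind 2-methylcyclopropyl, a 31-fold higher number from compound 2 to compound 4 (1.49 log units; beyond the scatter). Compound 1 stands at a limit, not a number: the limit of > 10000 nM in this assay, at which 1 of the 4 values shown sits.
The step to oxan-4-yl is thus a bound, not a measured size, an at least 34-fold lower number from compound 1 to compound 4 (1.53 log units; beyond the scatter).

Open, from the compounds shown here alone, is how a cyclohexyl group or a piperidin-4-yl amine on that carbonyl carbon would compare with oxan-4-yl. Also open, going by these compounds, is whether any larger ring could approach compound 2.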